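The source may report more compounds than this note shows. Statements on the series, on what has been measured and on what is new or still open speak of the compounds shown alone.

Measured in a functional assay on the whole organism (strain Kunming) with Mus musculus as the target, with a stated time of 0.5 h; a lower number here means that less compound is needed, a higher number that more compound is needed for the effect:
- Compound 1 `COc1cc(OC)c(OC)cc1/C=C/COC(=O)/C=C/c1ccccc1C(F)(F)F`: > 710 umol/kg
- Compound 2 `COc1cc(OC)c(OC)cc1/C=C/COC(=O)/C=C/c1cc(OC)c(OC)c(OC)c1`: > 450 umol/kg

Neither compound has yet given a number in this assay. Compound 1 stands only at a limit, > 710 umol/kg. Compound 2 likewise reaches only a limit, > 450 umol/kg. Among the compounds with values here, no measured step therefore links these two compounds, and their limits give no order between them.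

Compound 3 `COc1cc(OC)c(OC)cc1/C=C/COC(=O)/C=C/c1ccc(Cl)cc1` keeps the core of compound 1 and changes one group: 4-chlorophenyl in place of 2-(trifluoromethyl)phenyl on a double-bonded chain carbon bound to a double-bonded chain carbon. Within the data shown here, the only guide is that both measured neighbours ended at limits, so a clear gain in potency is not assumed, and compound 3 may well end at a limit too. The expected step of an at least 1.1-fold lower number from compound 1 to compound 3 (0.07 log units; that floor lies within the scatter) is none beyond the scatter. For compound 3 the estimated value is 600 umol/kg, with an expected range from 200 umol/kg to 1100 umol/kg.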

Compound 3, dose for half-maximal effect: > 514 umol/kg
Compound 3: only a limit was reported; the forecaster's own chance of this, stated with the estimate: 55%; the middle value is on the limit's open side.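

Compound 3, like compound 1, gave only a limit in this assay, so the step between compound 1 and compound 3 cannot be read. The compounds shown leave open whether any of them reaches a measurable half-maximal dose, and how they rank.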